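Acylating the hydroxymethyl of compound 2

The compounds below may be only part of what the source reports. "The series", "measured", "known", "first", "only" and "open" are said of these compounds alone.

Within the data shown here, in a functional assay on COLO 320 cells (Homo sapiens) for cytotoxicity, read by MTT assay, with a stated time of 4 h (on this read-out higher numbers stand for weaker inhibition and lower numbers for stronger inhibition), the series so far holds three compounds. Compound 1 (`COC(=O)C1=CO[C@@H](O[C@@H]2O[C@H](COC(c3ccccc3)(c3ccccc3)c3ccccc3)[C@@H](OC(=O)O)[C@H](OC(C)=O)[C@H]2OC(C)=O)[C@@H]2[C@@H](C)[C@@H](OC(C)=O)C[C@H]12`) gives 0.82 ug/mL in this assay and compound 3 (`CCCCCCCCCCCC(=O)OC[C@H]1O[C@@H](O[C@@H]2OC=C(C(=O)OC)[C@H]3C[C@H](OC(C)=O)[C@H](C)[C@@H]23)[C@H](OC(C)=O)[C@@H](OC(C)=O)[C@@H]1OC(C)=O`) gives 0.04 ug/mL there, the lower number of the two and so the stronger inhibition. Compound 2 (`COC(=O)C1=CO[C@@H](O[C@@H]2O[C@H](CO)[C@@H](OC(C)=O)[C@H](OC(C)=O)[C@H]2OC(C)=O)[C@@H]2[C@@H](C)[C@@H](OC(C)=O)C[C@H]12`) is reported as "not active" (no number reported) with no number attached, so it holds no place on the scale and serves only as a qualitative starting point.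

Compound 4 (`COC(=O)C1=CO[C@@H](O[C@@H]2O[C@H](COC(=O)C=C(C)C)[C@@H](OC(C)=O)[C@H](OC(C)=O)[C@H]2OC(C)=O)[C@@H]2[C@@H](C)[C@@H](OC(C)=O)C[C@H]12`) has not yet been measured. The structural change is (2-methylprop-1-en-1-yl)carbonyl in place of hydrogen on an oxygen on a saturated carbon and the hydroxymethyl becomes (((2-methylprop-1-en-1-yl)carbonyl)oxy)methyl, with the rest of the structure unchanged. Among the measured compounds shown here, no measured pair isolates this change, and the starting point has no number, so the size of the step in this assay cannot be stated. The expected direction is toward stronger inhibition, from no reported activity to a measurable value. For the measured compounds named here, this expectation has only two numbers to lean on, compound 3 at 0.04 ug/mL and compound 1 at 0.82 ug/mL in the same series, and a second reading without a number remains possible. The estimate for compound 4 is 0.4 ug/mL with an expected range of 0.04 ug/mL to 4 ug/mL as a working figure.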

Compound 4, half-maximal inhibitory concentration: 0.08 ug/mL
Compound 4: the middle estimate sits 5.0-fold (0.70 log units) above what was measured; the range from low to high includes it.
By their numbers in this assay, from the lowest: compounds 3 and 4 (each within the scatter of the next); then compound 1.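

In this assay compound 4 gives 0.08 ug/mL with (2-methylprop-1-en-1-yl)carbonyl on the oxygen of the hydroxymethyl, whereas compound 2, which keeps the free hydroxymethyl, is reported as not active; with no number for compound 2, the size of this step cannot be read. On the carbonyl carbon of this ester, 2-methylprop-1-en-1-yl in place of undecyl gives a 2.0-fold higher number from compound 3 to compound 4 (0.30 log units; within the scatter) in this assay and so does not separate the two esters. A measurable reading at this position therefore does not depend on the undecyl chain, at least for this pair, a point that compound 3 alone could not show.

The data give no reason for the difference between the free hydroxymethyl and its two esters. Still open, on these data alone, is whether the ester link itself matters or any substituent on this oxygen will do, which a methyl ether, a benzoyl ester or a simple acetyl ester at the same place would test, along with whether a carboxylic acid or an amine at the end of the chain keeps the reading.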